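The compounds below may be only part of what the source reports. "The series", "measured", "known", "first", "only" and "open" are said of these compounds alone.

Compound 1 `Cc1noc(-c2ccc(O[C@H]3CCC[C@H](C(=O)O)C3)cc2)c1COC(=O)N(C)CCC(C)C`: 0.002
Compound 2 `Cc1noc(-c2ccc(Oc3ccc(C(=O)O)cc3)cc2)c1NC(=O)O[C@H](C)c1ccccc1`: 0.001

Of the compounds shown here, two have been measured in an ADME assay on the whole organism (plasma, Rattus norvegicus, strain Sprague-Dawley) for protein binding, read by LC-MS, with a stated time of 24 h; a lower number here means a smaller unbound share, a higher number a larger unbound share of the compound. Compound 1 gives 0.002 and compound 2 gives 0.001, so compound 1 holds the highest number of the pair, although the two values lie within the scatter of each other. Both numbers describe a very small unbound share.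

Compound 3 `Cc1noc(-c2ccc(O[C@H]3CCC[C@H](C(=O)O)C3)cc2)c1CNC(=O)OCCC(C)(C)C` keeps the core of compound 1 and has the same atoms, joined differently. The change is a group of 10 heavy atoms (7 carbon, 1 nitrogen, 2 oxygen; no ring) in place of a group of 10 heavy atoms (7 carbon, 1 nitrogen, 2 oxygen; no ring), on a saturated chain carbon bound to an aromatic carbon. It sits on a saturated chain carbon bound to an aromatic carbon.

For the measured compounds named here, no measured pair in this set differs in one place, so the data give no direct guide to the size of such a step in this assay. The expectation rests on compound 1 at 0.002 as its starting point. The step of a 1.5-fold higher number from compound 1 to compound 3 (0.18 log units; within the scatter) is expected to stay within the scatter, with only a slight lean towards a larger unbound share.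

For compound 3 the estimated unbound fraction is 0.003, with an expected range from 0.001 to 0.008.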

Compound 3, unbound fraction: 0.001
Compound 3: the middle estimate sits 3.0-fold (0.48 log units) above what was measured; measured number inside the range.
By their numbers in this assay, from the lowest: compounds 2, 3 and 1 (each within the scatter of the next).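

For the compounds shown here, compound 3 supplies the first comparison in this set that differs in one place, and in this assay the step is a 2.0-fold lower number from compound 1 to compound 3 (0.30 log units; within the scatter), which lies within the scatter. On a saturated chain carbon bound to an aromatic carbon, the group that enters has 1 hydrogen-bond donor and the group that leaves has 0 hydrogen-bond donors, yet the two groups share the same atoms and this rearrangement does not move the unbound fraction beyond the scatter, so the value stays at a very small unbound share. Nothing among the data shown accounts for this result.

What the compounds shown leave open is whether this position can shift the unbound fraction at all when it carries a group of another kind, such as an amine or a carboxylic acid, or a longer chain, in place of these groups of 10 heavy atoms. A single step also cannot show whether the same exchange would behave alike on a different core, such as that of compound 2.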